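Replacing 4-methylphenyl in compound 2

This account rests on a few compounds, and the source may have more. Where it says the series, first, only, none or still open, it means among the compounds named here.

Compound 1 `CN(C)C(=O)c1cc2cnc(Nc3ccc(NC(=O)C4(C(=O)Nc5ccc(Cl)cc5)CC4)cc3)nc2n1C1CCCC1`: 95%
Compound 2 `Cc1ccc(NC(=O)C2(C(=O)Nc3ccc(Nc4ncc5cc(C(=O)N(C)C)n(C6CCCC6)c5n4)cc3)CC2)cc1`: 99.6%

In a functional assay on T47D cells (Homo sapiens) for inhibition, read by CCK-8 assay, with a stated time of 72 h, tested at 10 uM (on this read-out lower numbers stand for less inhibition of growth and higher numbers for more inhibition of growth at the one concentration tested), compound 2 gives 99.6% and stands level with compound 1 within the scatter. The move to compound 3 `CN(C)C(=O)c1cc2cnc(Nc3ccc(NC(=O)C4(C(=O)Nc5cccc(C(F)(F)F)c5)CC4)cc3)nc2n1C1CCCC1` puts 3-(trifluoromethyl)phenyl in place of 4-methylphenyl on an amide-type nitrogen on an amide-type nitrogen. For the measured compounds named here, the one measured step bearing on this, methyl in place of chloro on an aromatic carbon, gave a number 4.6 percentage points higher from compound 1 to compound 2 (within the scatter) and so stayed small. Going by the values given here, no measured compound carries trifluoromethyl, so only a modest downward drift is expected, none clearly beyond the scatter. The expected step is a number 7.6 percentage points lower from compound 2 to compound 3 (within the scatter) in this assay by this estimate. For compound 3 the estimate is 92% within an expected range from 72% to 100%.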

Compound 3, percent growth inhibition at one concentration: 92.7%
The estimate for compound 3 lay 0.7 percentage points below the measured number; low and high end bracket the measured number.
By their numbers in this assay, from the lowest: compounds 3, 1 and 2 (each within the scatter of the next).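

In this assay the step to 3-(trifluoromethyl)phenyl on the amide-type nitrogen gives a number 6.9 percentage points lower from compound 2 to compound 3 (within the scatter) and, set against 4-chlorophenyl, a number 2.3 percentage points lower from compound 1 to compound 3 (within the scatter) so this position has now taken a larger group, with 10 heavy atoms rather than 7, and a substituent at a different ring position without a step beyond the scatter. No measurement at hand explains this tolerance.

The compounds shown leave open whether a carboxylic acid or an aminomethyl group on this phenyl ring would hold the number. On these data alone, a cyclohexyl ring in place of the phenyl ring also remains untested here.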